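This account rests on a few compounds, and the source may have more. Where it says the series, first, only, none or still open, it means among the compounds named here.

Of the compounds shown here, three have so far been measured in a functional assay on CCRF-CEM cells (Homo sapiens) for inhibition, read by cell counting, with a stated time of 3 days; on this read-out higher numbers stand for weaker inhibition and lower numbers for stronger inhibition. Compound 1 `C=C(Br)C(=O)Nc1cccc(-c2cn3c(-c4ccccc4)csc3n2)c1` gives 2800 nM, compound 2 `C=C(Br)C(=O)Nc1cccc(-c2cn3nc(Cc4cccc(OC)c4)sc3n2)c1` gives 3100 nM, and compound 3 `COc1cccc(Cc2nn3cc(-c4cccc(N)c4)nc3s2)c1` gives 40000 nM. Compound 2 thus holds the second highest of the three numbers; its nearest neighbour is compound 1, whose number lies within the scatter of its own, while compound 3 sits far above it. For the measured compounds named here, the only step that joins two measured compounds in one place is a 13-fold higher number from compound 2 to compound 3 (1.11 log units; beyond the scatter); along it the (1-bromoethenyl)carbonyl group on the ring nitrogen is replaced by hydrogen.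

Compound 4 `C=C(Br)C(=O)Nc1cccc(-c2cn3nc(-c4ccccc4)sc3n2)c1` has not yet been measured. It keeps that group and differs from compound 2 in phenyl in place of 3-methoxybenzyl on an aromatic carbon of the five-membered aromatic ring with 2 nitrogen and 1 sulfur in the core. Going by the values given here, no measured step touches this kind of change. Among the compounds with values here, the only hint comes from compound 1, which carries a plain phenyl on its own core and whose number lies within the scatter of compound 2. The step from compound 2 is therefore expected to be a 1.0-fold lower number from compound 2 to compound 4 (0.01 log units; within the scatter), nothing beyond the scatter. Compound 4 is estimated at 3000 nM in this assay, with a likely range from 1200 nM to 7500 nM.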

Compound 4, half-maximal inhibitory concentration: 960 nM
Beside the measured number, compound 4's estimate is 3.1-fold (0.49 log units) above it; the measured number lies below the stated range.
By their numbers in this assay, from the lowest: compound 4; then compounds 1 and 2 (each within the scatter of the next); then compound 3.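

At this position, an aromatic carbon of the five-membered aromatic ring with 2 nitrogen and 1 sulfur, the choice of group affects the result in this assay: putting phenyl in place of 3-methoxybenzyl gives a 3.2-fold lower number from compound 2 to compound 4 (0.51 log units; beyond the scatter). For the compounds shown here, the earlier step, a 13-fold higher number from compound 2 to compound 3 (1.11 log units; beyond the scatter), concerned only the group on the ring nitrogen, so this is the first measured sign that the opposite end of the molecule also matters, although this step is modest and the earlier one large. Phenyl has fewer heavy atoms than 3-methoxybenzyl and no hydrogen-bond acceptor, but no measurement here indicates which of these differences, if either, accounts for the step.

From the compounds shown here alone, it remains open whether a plain benzyl group, which keeps the carbon link but lacks the methoxy group, would give a number closer to that of compound 2 or compound 4. Also unresolved are how an amine or a carboxylic acid on the phenyl ring of compound 4 would change the number, and whether phenyl would still give a lower number than 3-methoxybenzyl if the (1-bromoethenyl)carbonyl group were replaced by hydrogen, as in compound 3.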